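The compounds below may be only part of what the source reports. "The series", "measured", "known", "first", "only" and "open" are said of these compounds alone.

Working notes on the series, all on the shared core of compound 1 (`C=C1CCC2[C@](C)(CO)[C@H](O)CC[C@@]2(C)[C@@H]1CCn1cncn1`). In a functional assay on RAW264.7 cells (Mus musculus) for inhibition, read by Griess assay, with stated times of 3 h and 24 h (a higher number here means a weaker inhibitor, a lower number a stronger inhibitor), compound 1 gives > 100000 nM, which is a limit of the assay and not a number. Compound 2 (`C=C1CCC2[C@](C)(CO)[C@H](O)CC[C@@]2(C)[C@@H]1CCn1cnc2c(N)ncnc21`) gives > 100000 nM, also a limit. For the measured compounds named here, compound 3 (`C=C1CCC2[C@](C)(CO)[C@H](O)CC[C@@]2(C)[C@@H]1CCOc1ccc(C(C)(C)C)cc1`) gives 35800 nM, the only actual number so far. Compound 1 therefore has no measured potency to serve as a baseline, and it sits with compound 2 at the same limit.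

The next compound is compound 4 (`C=C1CCC2[C@](C)(CO)[C@H](O)CC[C@@]2(C)[C@@H]1CCOC(=O)c1cccnc1`), which has ((pyridin-3-yl)carbonyl)oxy in place of 1H-1,2,4-triazol-1-yl on a saturated chain carbon, two bonds along the chain from a saturated ring carbon.

Going by the values given here, no measured step is available to size this change, so any expectation is weakly grounded. Among the compounds with values here, compound 3, at 35800 nM, is the only compound with a number, and like compound 4 it joins an aromatic ring to the chain through oxygen. A modest shift towards stronger inhibition in this assay is therefore expected, with a real chance that compound 4 stays at the limit. The expected step is an at least 1.6-fold lower number from compound 1 to compound 4 (0.22 log units; that floor lies within the scatter). For compound 4 the estimated value is 60000 nM, with an expected range of 20000 nM to 100000 nM.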

Compound 4, half-maximal inhibitory concentration: > 50000 nM
Compound 4: no number, only a limit; the forecaster's own chance of this, stated with the estimate: 45%; the middle value is on the limit's open side.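

In this assay compound 4 gives > 50000 nM, which is a limit and not a number. For the compounds shown here, compound 1 gives > 100000 nM, also a limit, so no step from compound 1 to compound 4 can be read. The compounds shown leave open whether ((pyridin-3-yl)carbonyl)oxy in place of 1H-1,2,4-triazol-1-yl changes inhibition at all.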